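The compounds below may be only part of what the source reports. "The series", "measured", "known", "first", "only" and "open" are said of these compounds alone.

Measured compounds:
compound 1 `O=C(CC1CCOCC1)Nc1ccc(N2CCN(c3ccc(OC[C@@H]4CO[C@@](Cn5cncn5)(c5ccc(Cl)cc5Cl)O4)cc3)CC2)cc1` with 10000 nM in a functional assay on A549 cells (Homo sapiens) for inhibition, read by MTT assay, with a stated time of 48 h; a higher number here means a weaker inhibitor, a lower number a stronger inhibitor;
compound 2 `O=C(Nc1ccc(N2CCN(c3ccc(OC[C@@H]4CO[C@@](Cn5cncn5)(c5ccc(Cl)cc5Cl)O4)cc3)CC2)cc1)c1cccc(F)c1` with 6640 nM in this assay.

For the measured compounds named here, compound 2 gives the lowest of the two numbers, but the only measured step, a 1.5-fold lower number from compound 1 to compound 2 (0.18 log units; within the scatter), lies within the scatter, so compound 2 and compound 1 cannot be told apart. Compound 3 `O=C(Nc1ccc(N2CCN(c3ccc(OC[C@@H]4CO[C@@](Cn5cncn5)(c5ccc(Cl)cc5Cl)O4)cc3)CC2)cc1)c1ccc(F)c(F)c1` differs from compound 2 by fluoro in place of hydrogen on an aromatic carbon. Going by the values given here, no measured step adds a fluoro to an aromatic carbon; the one measured step exchanges the whole group on the carbonyl carbon and was itself within the scatter. Compound 3 is therefore expected to give a number in this assay close to compound 2, with a step of a 1.1-fold lower number from compound 2 to compound 3 (0.04 log units; within the scatter); the estimate is 6000 nM, within 2500 nM to 14000 nM.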

Compound 3, half-maximal inhibitory concentration: 8690 nM
Compound 3: the middle estimate sits 1.4-fold (0.16 log units) below what was measured; the range from low to high includes it.
By their numbers in this assay, from the lowest: compounds 2, 3 and 1 (each within the scatter of the next).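

Adding a fluoro to the 3-fluorophenyl group, at the carbon ortho to a fluoro group and para to a large group, gives a 1.3-fold higher number from compound 2 to compound 3 (0.12 log units; within the scatter) in this assay and so does not separate the two compounds. The 3,4-difluorophenyl group in place of (oxan-4-yl)methyl on the carbonyl carbon gives a 1.2-fold lower number from compound 1 to compound 3 (0.06 log units; within the scatter) and so separates neither, leaving all three compounds unresolved. Nothing at hand bears on this result. Going by these compounds, it stays open whether a nitrile, a methoxy group or an amine in place of a fluoro on this ring would move the number beyond the scatter.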